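Compound 3 Against Two Weak Binders

The source may hold more compounds than are shown below. What is called first, only, known or untested is meant among the compounds shown, and "the series" means these compounds.

Compound 2 `CCN(CC)c1cc(NC(=O)NNc2cc(-c3ccc(F)cc3)c3cnn(C)c3n2)cc(Cl)n1` and compound 1 `Cn1ncc2c(-c3ccc(F)cc3)cc(NNC(=O)Nc3cc(Cl)cc(Cl)c3)nc21` are the two measured compounds. In an assay on isolated protein for binding affinity to sphingosine 1-phosphate receptor 2 (Homo sapiens), read by surface plasmon resonance (a lower number here means tighter binding, a higher number weaker binding), compound 2 gives 3150 nM, while compound 1 gives 4980 nM; the two numbers lie within the scatter of each other, so neither stands apart. Compound 3 `Cn1ncc2c(-c3ccc(F)cc3)cc(NNC(=O)Nc3cc(Cl)nc(OCCF)c3)nc21` differs from compound 2 by one change: 2-fluoroethoxy in place of diethylamino on an aromatic carbon. Within the data shown here, no measured pair shows such a step, so no direction beyond the scatter is expected, and the step of a 1.1-fold higher number from compound 2 to compound 3 (0.05 log units; within the scatter) is an estimate. Compound 3 is expected to give 3500 nM, between 1500 nM and 9000 nM.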

Compound 3, dissociation constant: 2790 nM
Estimate against measurement, compound 3: 1.3-fold (0.10 log units) above, and the stated range covers the measured number.
By their numbers in this assay, from the lowest: compounds 3, 2 and 1 (each within the scatter of the next).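

In this assay, the aromatic carbon next to the ring nitrogen accepts 2-fluoroethoxy in place of diethylamino with a 1.1-fold lower number from compound 2 to compound 3 (0.05 log units; within the scatter), so this exchange does not separate the two compounds. Replacing 3,5-dichlorophenyl with 2-chloro-6-(2-fluoroethoxy)pyridin-4-yl gives a 1.8-fold lower number from compound 1 to compound 3 (0.25 log units; within the scatter), and none of the three compounds stands apart. No measurement available here accounts for these results. Going by these compounds, whether a morpholine ring, a carboxylic acid or a longer alkoxy chain on this carbon would move the number beyond the scatter remains open.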